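The source may report more compounds than this note shows. Statements on the series, on what has been measured and on what is new or still open speak of the compounds shown alone.

Compound 1 `CCCCCCCCCCCSC(=S)C1=C(Nc2ccc(Cl)cc2)CC(C)(C)CC1=O` gives > 20 ug/mL in a functional assay on PBMC cells (Homo sapiens) for inhibition, read by ELISA, with a stated time of 18 h (a higher number here means a weaker inhibitor, a lower number a stronger inhibitor), a limit of the assay rather than a number.
Compound 2 `CC(=O)OC[C@H]1O[C@@H](SC(=S)C2=C(Nc3ccc(Cl)cc3)CC(C)(C)CC2=O)[C@H](OC(C)=O)[C@@H](OC(C)=O)[C@@H]1OC(C)=O` gives 3.5 ug/mL in this assay.
Compound 3 `CCCCCCCCCCCSC(=S)C1=C(Nc2ccc(Br)cc2)CC(C)(C)CC1=O` gives > 20 ug/mL in this assay, again a limit.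

Compound 1 and compound 3 share one core and differ by bromo in place of chloro on an aromatic carbon. Because (the limit of > 20 ug/mL in this assay, at which 2 of the 3 values shown sit), the step that the two limits leave unreadable from compound 1 to compound 3 cannot be read. Compound 2 carries another core; the difference between the two cores is not broken down here. Among the measured compounds shown here, compound 2 holds the only number in this assay. The unmeasured compound 4 `CC(=O)OC[C@H]1O[C@@H](SC(=S)C2=C(Nc3ccc(Br)cc3)CC(C)(C)CC2=O)[C@H](OC(C)=O)[C@@H](OC(C)=O)[C@@H]1OC(C)=O` differs from compound 2 by bromo in place of chloro on an aromatic carbon, the same change as from compound 1 to compound 3. As that earlier step is unreadable, the expectation for compound 4 rests on compound 2 alone and its value of 3.5 ug/mL. Compound 4 is therefore expected to give 4 ug/mL in this assay. The expected step of a 1.1-fold higher number from compound 2 to compound 4 (0.06 log units; within the scatter) is a small one, with wide uncertainty.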

Compound 4, half-maximal inhibitory concentration: 3.4 ug/mL
Beside the measured number, compound 4's estimate is 1.2-fold (0.07 log units) above it; low and high end bracket the measured number.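

In this assay, bromo in place of chloro on an aromatic carbon gives a 1.0-fold lower number from compound 2 to compound 4 (0.01 log units; within the scatter), so on the core of compound 2 the two halogens cannot be told apart. Among the compounds shown here, this is the only readable instance of the change, so it does not show that the change behaves alike on both cores. On the core of compound 1 the same change cannot be read: the limit of > 20 ug/mL in this assay, at which 2 of the 4 values shown sit.

The compounds shown leave open whether a group other than a halogen, such as methoxy or an amine, in the same place on the aromatic ring would fit the value of compound 2. They also leave open which part of the difference between the two cores matters in this assay.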